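The compounds below may be only part of what the source reports. "The series", "measured", "known", "first", "only" and "open" are said of these compounds alone.

Going by the values given here, compound 2 `O=C(OC1(C(=O)Nc2ccc([N+](=O)[O-])cc2)CCCCC1)c1ccc(Br)cc1` holds the higher of the two numbers so far known in a functional assay on HepG2 cells (Homo sapiens) for inhibition, read by MTT assay, with a stated time of 72 h; on this read-out higher numbers stand for weaker inhibition and lower numbers for stronger inhibition: compound 2 gives 284 nM, while compound 1 `O=C(OC1(C(=O)Nc2ccc([N+](=O)[O-])cc2)CCCCC1)c1ccc(Cl)cc1` gives 21.8 nM. Among the compounds with values here, the single measured step, a 13-fold higher number from compound 1 to compound 2 (1.11 log units; beyond the scatter), lies well beyond the scatter. Compound 3 `O=C(OC1(C(=O)Nc2ccc([N+](=O)[O-])cc2)CCCCC1)c1ccc([N+](=O)[O-])cc1` differs from compound 2 by nitro in place of bromo on an aromatic carbon. Within the data shown here, the measured step swaps one halogen for another, whereas the change from compound 2 to compound 3 puts a nitro group in place of a halogen, so no measured step matches it directly. What the measured step does show is that a change at this aromatic carbon can move this assay by a large amount, but it gives no direction for a nitro. The step of a 1.9-fold lower number from compound 2 to compound 3 (0.28 log units; within the scatter) is therefore expected to be modest and of uncertain direction. Compound 3 is estimated to give 150 nM in this assay, with a range from 30 nM to 800 nM.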

Compound 3, half-maximal inhibitory concentration: 14.1 nM
Compound 3: middle estimate off by 11-fold (1.03 log units), on the high side; the whole stated range lies above it.
By their numbers in this assay, from the lowest: compounds 3 and 1 (each within the scatter of the next); then compound 2.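

In this assay the change from 4-bromophenyl to 4-nitrophenyl gives a 20-fold lower number from compound 2 to compound 3 (1.30 log units; beyond the scatter), so a nitro on this aromatic carbon does not share the weak inhibition seen with bromo. Set against chloro, the nitro gives a 1.5-fold lower number from compound 1 to compound 3 (0.19 log units; within the scatter), which lies within the scatter, so among the three groups shown only bromo stands apart. Nothing available here explains why bromo differs from the other two groups.

The compounds shown leave open whether an amine, a methoxy group or a carboxylic acid on this same carbon would align with chloro and nitro or with bromo. They also leave open whether the gap between bromo and the other two groups would persist on a core other than the shared one.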